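Swapping the dimethoxyphenyl of compound 1 for a bromophenyl

The compounds below may be only part of what the source reports. "The series", "measured", "known", "first", "only" and "open" are said of these compounds alone.

Compound 1 `COc1cc(OC)c(OC)cc1/C=C/COC(=O)/C=C/c1ccc(OC)c(OC)c1` is an ester in which a 3,4-dimethoxyphenyl group sits on a double-bonded chain carbon. In a functional assay on the whole organism (strain Kunming) with Mus musculus as the target, with a stated time of 0.5 h, at a dose of 100 mg/kg by the intraperitoneal route (a higher number here means a weaker effect of the compound at the dose given, a lower number a stronger effect), compound 1 gives 100%. Two companions share its core. Compound 2 `COc1cc(OC)c(OC)cc1/C=C/COC(=O)/C=C/c1c(OC)ccc(OC)c1OC` gives 100% in this assay, and compound 3 `COc1cc(OC)c(OC)cc1/C=C/COC(=O)/C=C/c1cc(OC)c(OC)c(OC)c1` gives 100%. For the measured compounds named here, compound 1 therefore stands level with compound 2 and compound 3 at the digits reported; the only single-point step among them, no change at the digits printed from compound 1 to compound 3 (within the scatter), is no change within the scatter.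

Compound 4 `COc1cc(OC)c(OC)cc1/C=C/COC(=O)/C=C/c1cccc(Br)c1` has not yet been measured. It differs from compound 1 in one place: 3-bromophenyl in place of 3,4-dimethoxyphenyl on a double-bonded chain carbon bound to a double-bonded chain carbon. Going by the values given here, the one measured step that touches this region, no change at the digits printed from compound 1 to compound 3 (within the scatter), added a methoxy to the aromatic ring and left the read-out unchanged within the scatter. The change to compound 4 is larger in kind, since it removes both methoxy groups and brings in a bromine, so the earlier step is only a loose guide. On that basis the expected step is no change at the digits printed from compound 1 to compound 4 (within the scatter), no change beyond the scatter, with the uncertainty lying mostly on the lower side. Compound 4 is therefore estimated at 100%, within a range from 75% to 100%.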

Compound 4, a percentage reported as activity, at one dose (the size of the read-out at that dose, not a potency): 100%
Estimate against measurement, compound 4: no gap at the digits printed; the measured number falls inside the stated range.
By their numbers in this assay, from the lowest: compounds 1, 2, 3 and 4 (each within the scatter of the next).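

In this assay, replacing 3,4-dimethoxyphenyl with 3-bromophenyl gives no change at the digits printed from compound 1 to compound 4 (within the scatter), a wider test of this position than the single added methoxy seen earlier. Here both methoxy groups leave, a bromine enters, the group shrinks in heavy atoms and it loses its hydrogen-bond acceptors, yet the read-out does not move beyond the scatter. The ring at this place therefore does not need methoxy groups to give this result, although neither this swap nor the earlier step produces a lower number, which would mean a stronger effect, and nothing available explains why the result holds.

The compounds shown leave open whether any change at this place can bring the number down, for example an amine or a carboxylic acid on the ring, or a longer chain in place of the ring. They also leave open whether changes elsewhere on the shared core, such as replacing the ester with an amide, would separate compounds that this assay cannot tell apart here.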